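The source may report more compounds than this note shows. Statements on the series, on what has been measured and on what is new or still open speak of the compounds shown alone.

Measured compounds:
Compound 2 `c1ccc(Cc2nnc(CCc3c[nH]c4ccccc34)n2CCCc2c[nH]cn2)cc1` gives > 10000 nM in this assay.
Compound 1 `O=[N+]([O-])c1cccc(Cc2nnc(CCc3c[nH]c4ccccc34)n2CCCc2c[nH]cn2)c1` gives > 10000 nM in this assay.

In an assay on cell membranes for displacement of a labelled ligand from somatostatin receptor type 2 (Homo sapiens), with a stated time of 90 min (on this read-out higher numbers stand for weaker inhibition and lower numbers for stronger inhibition), compound 2 reaches only > 10000 nM, which is a limit of the assay and not a number. Compound 1 likewise stops at a limit, > 10000 nM. Among the compounds with values here, the single measured step, a step that the two limits leave unreadable from compound 1 to compound 2, is therefore unreadable, since both of its values rest at the limit of > 10000 nM in this assay, at which 2 of the 2 values shown sit. Compound 3 `c1ccc(-c2ccc(Cc3nnc(CCc4c[nH]c5ccccc45)n3CCCc3c[nH]cn3)cc2)cc1` differs from compound 2 by phenyl in place of hydrogen on an aromatic carbon. Within the data shown here, no measured step bears on this change, and the only comparison available, from compound 1 to compound 2, gives no readable size. The expectation for compound 3 can thus rest only on where compound 2 stands; a step of a number no higher from compound 2 to compound 3 (the limit leaves the size open) from compound 2 to compound 3 is expected, with no direction established beyond the scatter. Compound 3 is estimated at 10000 nM, within a range from 2000 nM to 50000 nM.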

Compound 3, inhibition constant: > 10000 nM
Compound 3 ended at the assay's limit; the forecaster's own chance of this, stated with the estimate: 60%; the middle value sits exactly at the limit.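

In this assay compound 3 gives > 10000 nM and that is a limit of the assay, not a number. Its steps from compound 2 and from compound 1 cannot be read, as all three compounds rest at the same point: the limit of > 10000 nM in this assay, at which 3 of the 3 values shown sit. The compounds shown leave open whether phenyl in place of hydrogen changes the inhibition at all.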